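This account rests on a few compounds, and the source may have more. Where it says the series, first, only, none or still open, it means among the compounds named here.

Measured compounds:
compound 1, `CCCNC(=O)c1oc2ccc(Nc3ncnc4ccc(Cl)nc34)cc2c1C` — > 10000 nM
compound 2, `O=C(c1cccc(C#Cc2ccccc2Nc2ncnc3ccc(Cl)nc23)c1)N1CCOCC1` — > 10000 nM

In an assay on isolated protein for inhibition of MAP kinase-interacting serine/threonine-protein kinase 1 (Homo sapiens), read by HTRF, in the presence of a further agent that is not named here (a higher number here means a weaker inhibitor, a lower number a stronger inhibitor), compound 1 gives > 10000 nM, which is a limit of the assay rather than a number. Compound 2 in this assay likewise gives > 10000 nM, also a limit. Compound 1 thus sits at the limit of > 10000 nM in this assay, at which 2 of the 2 values shown sit, and nothing in the numbers shown separates it from compound 2. Going by the values given here, no step between measured compounds is available.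

Compound 3, `CNC(=O)c1oc2ccc(Nc3ncnc4ccc(Cl)nc34)cc2c1C`, is the compound still to be measured in this assay. It differs from compound 1 by hydrogen in place of ethyl on a saturated chain carbon bound to an amide-type nitrogen. Among the compounds with values here, with both measured compounds at the limit, there is no measured step from which a direction can be drawn, and no movement beyond the usual scatter is expected from going from propylcarbamoyl to methylcarbamoyl. Compound 3 is expected at 20000 nM, within 5000 nM to 100000 nM, most likely reported again only as a limit. The estimated step is a step that the limit leaves unreadable from compound 1 to compound 3, essentially none.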

Compound 3, half-maximal inhibitory concentration: > 10000 nM
Compound 3: only a limit was reported (the forecaster's own chance of this, stated with the estimate: 85%); the middle value lies beyond the limit too.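

No step can be read from compound 1 to compound 3 in this assay, as both results are limits and not numbers. The compounds shown leave open how strongly any of them inhibits the kinase, and whether going from propylcarbamoyl to methylcarbamoyl changes anything, with every value at one point: the limit of > 10000 nM in this assay, at which 3 of the 3 values shown sit.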